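From Phenoxy to Anilino: Predicting the Next Compound

The source may report more compounds than this note shows. Statements on the series, on what has been measured and on what is new or still open speak of the compounds shown alone.

So far, three compounds have been measured in a functional assay on CHO cells for antagonist activity at melanin-concentrating hormone receptor 1 (Homo sapiens), read by inositol phosphate accumulation; a higher number here means a weaker inhibitor, a lower number a stronger inhibitor. Compound 1 `CCN1CCCC1CNC(=O)c1ccc(NC(=O)Nc2ccc(Oc3ccccc3)cc2)cc1` gives 1300 nM in this assay. Compound 2 `COc1cc(NC(=O)Nc2ccc(Oc3ccccc3)cc2)ccc1C(=O)NCCCN1CCCCC1` gives 240 nM in this assay. Compound 3 `COc1cc(NC(=O)Nc2cccc(Oc3ccccc3)c2)ccc1C(=O)NCCCN1CCCCC1` gives 30 nM in this assay, the lowest number of the three. Its gap to compound 2 and its larger gap to compound 1 both lie beyond the usual scatter, so compound 3 is the strongest inhibitor among the measured set.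

The next compound, compound 4 `COc1cc(NC(=O)Nc2cccc(Nc3ccccc3)c2)ccc1C(=O)NCCCN1CCCCC1`, keeps everything in compound 3 except one change: anilino in place of phenoxy on an aromatic carbon. Going by the values given here, no pair of measured compounds shows this kind of exchange, so there is no measured step to lean on, and the expectation rests only on the value of compound 3 and the modest nature of the change.

The expected step is a small weakening, a 2.0-fold higher number from compound 3 to compound 4 (0.30 log units; within the scatter), which may fall within the scatter or just beyond it. Compound 4 is therefore estimated to give about 60 nM in this assay, with a likely range from 15 nM to 250 nM, so that it should remain clearly stronger than compound 1 and close to compound 2 or better.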

Compound 4, half-maximal inhibitory concentration: 20 nM
Beside the measured number, compound 4's estimate is 3.0-fold (0.48 log units) above it; measured number inside the range.
By their numbers in this assay, from the lowest: compounds 4 and 3 (each within the scatter of the next); then compound 2; then compound 1.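

In this assay, anilino in place of phenoxy on an aromatic carbon gives a 1.5-fold lower number from compound 3 to compound 4 (0.18 log units; within the scatter), so this exchange produces no readable difference between the two compounds. Going by these compounds alone, this is the first measured exchange at this place on the ring, meta to a large group, and it shows that a hydrogen-bond donor, which anilino carries and phenoxy does not, can stand there while the number stays within the scatter. No measurement shown here accounts for this outcome, so the result describes what happens in this assay but gives no explanation for it.

The compounds shown leave open how much the atom linking the outer ring to the core matters, since only oxygen and nitrogen appear in that role, and a benzyl or phenylthio group would extend the comparison to a carbon or sulfur link. They also leave open whether the hydrogen on the anilino nitrogen plays any part in the result, a question that an anilino carrying a methyl on that nitrogen would address.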